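Swapping a para substituent on a ketooxazole inhibitor

A few compounds are considered here, and "the series" means these few. Any claim that something is new, unique, unknown or untested is made for them only; others in the source may bear on it.

Measured compounds:
compound 1, `O=C(CCCCCCc1ccccn1)c1ncc(-c2ccccn2)o1`, 120 nM
compound 2, `CC(C)(C)OC(=O)Nc1ccc(CCCCCCC(=O)c2ncc(-c3ccccn3)o2)cc1`, 5.6 nM

Both compounds were tested in an assay for inhibition of Fatty-acid amide hydrolase 1 (Rattus norvegicus); on this read-out higher numbers stand for weaker inhibition and lower numbers for stronger inhibition. Compound 1 gives 120 nM, while compound 2 gives 5.6 nM; compound 2 therefore has the lowest number of the two shown, and the gap to compound 1 lies well beyond the scatter of the method.

Compound 3, `CSc1ccc(CCCCCCC(=O)c2ncc(-c3ccccn3)o2)cc1`, has not yet been measured. It differs from compound 2 in one place: methylsulfanyl in place of (tert-butoxycarbonyl)amino on an aromatic carbon. Among the compounds with values here, no pair of measured compounds shows a change of this kind, so the size of the step is uncertain. Since the shared core and the chain remain as in compound 2, a step no larger than the scatter, or a slight shift towards a higher number, is expected, as a 1.4-fold higher number from compound 2 to compound 3 (0.15 log units; within the scatter) expresses. On that basis compound 3 is estimated at 8 nM, with a range from 2 nM to 30 nM.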

Compound 3, inhibition constant: 2.5 nM
The estimate for compound 3 lay 3.2-fold (0.51 log units) above the measured number; the range from low to high includes it.
By their numbers in this assay, from the lowest: compound 3; then compound 2; then compound 1.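

In this assay the bulky (tert-butoxycarbonyl)amino group turns out not to be required at this place on the ring: methylsulfanyl, a smaller group with no hydrogen-bond donor, gives a 2.2-fold lower number from compound 2 to compound 3 (0.35 log units; beyond the scatter), a modest gain rather than a loss. Having 4-(methylsulfanyl)phenyl on the chain instead of pyridin-2-yl gives a 48-fold lower number from compound 1 to compound 3 (1.68 log units; beyond the scatter), so the group carried by the chain has a large influence on this number. Nothing available here accounts for either step.

On these data alone, it remains open whether the sulfur atom itself matters, or whether another small group, such as an amine, a methoxy group or a carboxylic acid, would serve equally well at this place. How a longer chain would behave alongside methylsulfanyl is also an open question.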